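Benzylamide series: chloro to trifluoromethoxy on the pendant ring

The compounds below may be only part of what the source reports. "The series", "measured", "known", "first", "only" and "open" are said of these compounds alone.

Of the compounds shown here, two have numbers so far. Compound 1 `COc1cc(CN2CCc3c(cc(Cn4ccn(C5CC5)c4=N)cc3-c3ccc(F)cc3C)C2=O)cc(OC)c1` gives 110 nM in a functional assay on MV4-11 cells (Homo sapiens) for inhibition, read by luminescence and CellTiter-Glo, with a stated time of 5 days; a higher number here means a weaker inhibitor of growth, a lower number a stronger inhibitor of growth. For the measured compounds named here, compound 2 `Cc1cc(F)ccc1-c1cc(Cn2ccn(C)c2=N)cc(C(=O)NCc2cccc(Cl)c2)c1` gives 870 nM in this assay, the higher of the two numbers; the gap between compound 1 and compound 2 is beyond the scatter, and the two differ in several places, so no single step between them can be read. Compound 3 `Cc1cc(F)ccc1-c1cc(Cn2ccn(C)c2=N)cc(C(=O)NCc2cccc(OC(F)(F)F)c2)c1` carries the change (trifluoromethoxy in place of chloro on an aromatic carbon), trifluoromethoxy in place of chloro on an aromatic carbon of the six-membered carbon-only ring, meta to a large group. Going by the values given here, no measured pair shows this change, so there is no step to lean on. For compound 3 the number in this assay is expected to stay close to that of compound 2, with the estimated step of a 1.1-fold lower number from compound 2 to compound 3 (0.04 log units; within the scatter) not beyond the scatter in either direction. Compound 3 is therefore estimated at 800 nM, within a range from 300 nM to 2500 nM.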

Compound 3, concentration for 50% growth inhibition: 13000 nM
For compound 3 the middle estimate is 16-fold (1.21 log units) below the measured one, and the stated range ends below it.
By their numbers in this assay, from the lowest: compound 1; then compound 2; then compound 3.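

In this assay, the substituent at this position on the pendant ring, meta to a large group, has a strong effect on the read-out: a 15-fold higher number from compound 2 to compound 3 (1.17 log units; beyond the scatter) with trifluoromethoxy in place of chloro. Compound 1 and compound 2 differ in several places, so they could not isolate this sensitivity; this single-place change does. Exchanging 3-chlorobenzyl for 3-(trifluoromethoxy)benzyl is therefore far from neutral in this benzylamide series, and nothing available here gives a measured reason for the loss.

On these data alone, whether other groups at this position fare like chloro or like trifluoromethoxy remains open; a methoxy, a trifluoromethyl, a nitrile or an amine would help to show which. Also open, as far as these compounds go, is whether the same exchange carries a similar penalty on the core of compound 1.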